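Dienone series: furan in place of the methylphenyl ring

This account rests on a few compounds, and the source may have more. Where it says the series, first, only, none or still open, it means among the compounds named here.

Within the data shown here, the three measured members share one core and differ only on the aromatic ring. Compound 1 `CC1=C(/C=C/C(=O)/C=C/c2ccc(C#N)cc2)C(C)(C)CCC1` gives 13200 nM in a functional assay on MCF7 cells (Homo sapiens) for cytotoxicity, read by sulforhodamine B assay, with a stated time of 48 h; a lower number here means a stronger inhibitor, a higher number a weaker inhibitor. Compound 2 `COc1ccc(/C=C/C(=O)/C=C/C2=C(C)CCCC2(C)C)cc1` gives 19600 nM in this assay, and compound 3 `CC1=C(/C=C/C(=O)/C=C/c2ccc(C)cc2)C(C)(C)CCC1` gives 23800 nM. The steps among them are all small: a 1.5-fold higher number from compound 1 to compound 2 (0.17 log units; within the scatter), a 1.8-fold higher number from compound 1 to compound 3 (0.26 log units; within the scatter) and a 1.2-fold higher number from compound 2 to compound 3 (0.08 log units; within the scatter). Compound 3 stands with the highest number of the three, but its gaps to compound 2 and to compound 1 both fall within the scatter, so no ordering of the three can be read from these numbers.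

Compound 4 `CC1=C(/C=C/C(=O)/C=C/c2ccoc2)C(C)(C)CCC1` is not yet measured. Relative to compound 3 the change is furan-3-yl in place of 4-methylphenyl on a double-bonded chain carbon bound to a double-bonded chain carbon. Among the measured compounds shown here, none of the measured steps bears on this change directly: each of them swaps one group on the aromatic ring, whereas here the whole ring is exchanged. What the measured steps do show is that changes at this end of the molecule left this assay essentially unmoved. On that basis a step within the scatter is expected, a 1.0-fold higher number from compound 3 to compound 4 (0.00 log units; within the scatter), with a wide range because the data hold no ring exchange. Compound 4 is therefore estimated at 24000 nM in this assay, between 8000 nM and 70000 nM.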

Compound 4, half-maximal inhibitory concentration: 100000 nM
For compound 4 the middle estimate is 4.2-fold (0.62 log units) below the measured one; measured number outside the range, above it.
By their numbers in this assay, from the lowest: compounds 1, 2 and 3 (each within the scatter of the next); then compound 4.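

Among these compounds, exchanging 4-methylphenyl for furan-3-yl on a double-bonded chain carbon bound to a double-bonded chain carbon is the first change to move the number in this assay beyond the scatter, with a 4.2-fold higher number from compound 3 to compound 4 (0.62 log units; beyond the scatter). This position is therefore not indifferent to the ring it carries: swaps of a single group on the aromatic ring stayed within the scatter, as in a 1.8-fold higher number from compound 1 to compound 3 (0.26 log units; within the scatter), whereas this ring exchange gives a weaker inhibitor, though the step is modest. No measurement shown here bears on the reason for this step.

The exchange alters ring size and brings in a ring oxygen and a hydrogen-bond acceptor together, so this single step leaves open which of these changes goes with the higher number. Also open, going by these compounds, is how the six-membered aromatic ring of carbon only would stand in this assay with an amine or a carboxylic acid in place of the methyl of 4-methylphenyl.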